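The source may hold more compounds than are shown below. What is called first, only, known or untested is meant among the compounds shown, and "the series" means these compounds.

Series notes, solubility. Compound 1 `COc1ccc2nc(C)cc(OCC(=O)Nc3cccc(C)c3)c2c1` and compound 2 `COc1ccc2nc(C)cc(OCC(=O)Nc3ccncc3)c2c1` share one core and differ only in the aryl group carried on the amide-type nitrogen. In a physicochemical assay for solubility, in phosphate buffer, measured as kinetic solubility, with a stated time of 1 h, at pH 7.4 (a lower number here means a less soluble compound, a higher number a more soluble compound), compound 1 gives 193000 nM; in this assay compound 2 gives 91500 nM. Going by the values given here, compound 2 thus holds the lower of the two numbers measured so far, and the single measured step, a 2.1-fold lower number from compound 1 to compound 2 (0.32 log units; beyond the scatter), is modest though beyond the scatter. Compound 3 `COc1ccc2nc(C)cc(OCC(=O)Nc3cc(C)nc(C)n3)c2c1` is the next member to be run in this assay. It differs from compound 2 in one place: 2,6-dimethylpyrimidin-4-yl in place of pyridin-4-yl on an amide-type nitrogen. Among the compounds with values here, the one measured step touches the same position, but there a 3-methylphenyl gave way to a pyridin-4-yl, whereas here a pyridin-4-yl gives way to a 2,6-dimethylpyrimidin-4-yl; no measured pair shows an exchange of this kind. With only a 2.1-fold lower number from compound 1 to compound 2 (0.32 log units; beyond the scatter) as a guide, and that step modest, a change of similar or smaller size in this assay is expected, its direction undetermined, so the estimate keeps compound 3 close to where compound 2 stands. Compound 3 is expected to give 100000 nM in this assay, within 40000 nM to 250000 nM. This corresponds to an expected step of a 1.1-fold higher number from compound 2 to compound 3 (0.04 log units; within the scatter).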

Compound 3, solubility: 5000 nM
Estimate against measurement, compound 3: 20-fold (1.30 log units) above; the whole stated range lies above it.
By their numbers in this assay, from the lowest: compound 3; then compound 2; then compound 1.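

Working notes on the amide-type nitrogen: in this assay, this position can carry a far larger step than the earlier pair showed, since the modest change (a 2.1-fold lower number from compound 1 to compound 2 (0.32 log units; beyond the scatter)) is now followed by a large one (an 18-fold lower number from compound 2 to compound 3 (1.26 log units; beyond the scatter)). The 2,6-dimethylpyrimidin-4-yl group also stands well apart from the 3-methylphenyl group (a 39-fold lower number from compound 1 to compound 3 (1.59 log units; beyond the scatter)), so the two aromatic groups that carry ring nitrogen, pyridin-4-yl and 2,6-dimethylpyrimidin-4-yl, do not sit together at one level, and ring nitrogen alone does not order the three compounds. Nothing available on these compounds accounts for the size of the step from pyridin-4-yl to 2,6-dimethylpyrimidin-4-yl.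

Because that exchange alters the ring hetero atoms and adds two methyl groups in one move, the compounds shown cannot assign the step to either part, and a pyrimidin-4-yl group without methyl groups, or a pyridin-4-yl group carrying the methyl groups, would separate them. Also open, going by these compounds, is how this assay reads an aryl group bearing an amine or a carboxylic acid at the same position.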